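A few compounds are considered here, and "the series" means these few. Any claim that something is new, unique, unknown or untested is made for them only; others in the source may bear on it.

Compound 1 `c1cnc2cc3c(cc2c1)C1CNCC3C1` is the parent of this small set. In an assay for binding affinity to Neuronal acetylcholine receptor; alpha4/beta2 (Rattus norvegicus) (a lower number here means a stronger inhibitor, a higher number a weaker inhibitor), compound 1 gives 1.6 nM, the lowest of the three numbers recorded so far. Compound 3 `Cc1ccnc2cc3c(cc12)C1CNCC3C1` gives 1.8 nM, and the step of a 1.1-fold higher number from compound 1 to compound 3 (0.05 log units; within the scatter) lies within the scatter. Compound 2 `c1ccc(-c2cnc3cc4c(cc3c2)C2CNCC4C2)cc1` gives 132 nM, and the step of an 83-fold higher number from compound 1 to compound 2 (1.92 log units; beyond the scatter) is large.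

Compound 4 `Cc1ccc2cc3c(cc2n1)C1CNCC3C1` has not yet been measured. It differs from compound 1 in one place:
methyl in place of hydrogen on an aromatic carbon
The entering group sits on the six-membered aromatic ring with one nitrogen, next to the ring nitrogen.

The measured step that bears most directly on this change is a 1.1-fold higher number from compound 1 to compound 3 (0.05 log units; within the scatter), which shows that a methyl on an aromatic carbon of the shared core left the number essentially unchanged. The step of an 83-fold higher number from compound 1 to compound 2 (1.92 log units; beyond the scatter) involved a phenyl, a far larger group, and so says little about a single methyl. The methyl of compound 4 sits at a different position from that of compound 3, so some shift cannot be excluded, but none beyond the scatter is anticipated. The expected step is therefore a 1.6-fold higher number from compound 1 to compound 4 (0.19 log units; within the scatter). Compound 4 is estimated at 2.5 nM, with a range from 1 nM to 8 nM.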

Compound 4, inhibition constant: 0.76 nM
The estimate for compound 4 lay 3.3-fold (0.52 log units) above the measured number, and the stated range ends above it.
By their numbers in this assay, from the lowest: compound 4; then compounds 1 and 3 (each within the scatter of the next); then compound 2.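

In this assay, methyl in place of hydrogen next to the ring nitrogen gives a 2.1-fold lower number from compound 1 to compound 4 (0.32 log units; beyond the scatter) and this modest step lies beyond the scatter, so a small group at this position goes with a lower number rather than merely leaving the number in place. The earlier methyl step, a 1.1-fold higher number from compound 1 to compound 3 (0.05 log units; within the scatter), lay within the scatter, so the two steps together show that the same exchange of hydrogen for methyl can read differently depending on where it falls on the shared core. No measurement shown accounts for the lower number at this position.

The compounds shown leave open whether the lower number belongs to methyl alone or extends to other groups here, such as an ethyl, a methoxy group or an amine. They also leave open whether a phenyl at this position would raise the number as far as in an 83-fold higher number from compound 1 to compound 2 (1.92 log units; beyond the scatter), since the phenyl of compound 2 sits elsewhere on the shared core.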